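Swapping the Aryl Substituent on a Thiourea Antagonist

This account rests on a few compounds, and the source may have more. Where it says the series, first, only, none or still open, it means among the compounds named here.

Two compounds have so far been measured in a functional assay for antagonist activity at Neuropeptide Y receptor type 2 (Homo sapiens); a lower number here means a stronger inhibitor, a higher number a weaker inhibitor:

Compound 1, `OC(c1ccccc1)(c1ccccc1)C1CCN(C(=S)Nc2ccc(C(F)(F)F)cc2)CC1`, gives 178 nM.
Compound 2, `CCN(CC)c1ccc(NC(=S)N2CCC(C(O)(c3ccccc3)c3ccccc3)CC2)cc1`, gives 72 nM.

Among the compounds with values here, compound 2 stands lowest of the two numbers; the single measured step, a 2.5-fold lower number from compound 1 to compound 2 (0.39 log units; beyond the scatter), separates it from compound 1, and that step is beyond the usual scatter of this assay.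

Compound 3, `CCOC(=O)c1ccc(NC(=S)N2CCC(C(O)(c3ccccc3)c3ccccc3)CC2)cc1`, has not yet been measured. It differs from compound 2 in one place: ethoxycarbonyl in place of diethylamino on an aromatic carbon. Within the data shown here, only one measured step bears on this change, and only loosely, since it concerns the same place on the ring but a different pair of groups: a 2.5-fold lower number from compound 1 to compound 2 (0.39 log units; beyond the scatter). That step shows the number moved by a modest amount when the group at this place was exchanged, so a change of similar size in either direction is plausible for compound 3, with no measured comparison that points firmly one way. Taking the swap in compound 3 as a further departure from the group that gave the lowest number, the expected value for compound 3 in this assay is 150 nM, with a range from 50 nM to 450 nM. This estimate for compound 3 amounts to a 2.1-fold higher number from compound 2 to compound 3 (0.32 log units; beyond the scatter).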

Compound 3, half-maximal inhibitory concentration: 207 nM
For compound 3 the middle estimate is 1.4-fold (0.14 log units) below the measured one, within the range that was stated.
By their numbers in this assay, from the lowest: compound 2; then compounds 1 and 3 (each within the scatter of the next).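

In this assay, replacing diethylamino with ethoxycarbonyl gives a 2.9-fold higher number from compound 2 to compound 3 (0.46 log units; beyond the scatter) even though the two groups have the same number of heavy atoms, so that count alone does not settle the number at this place on the ring. Trifluoromethyl and ethoxycarbonyl, which differ in makeup, cannot be told apart here, with a 1.2-fold higher number from compound 1 to compound 3 (0.07 log units; within the scatter) as the step between them, so among these three groups only diethylamino stands out and compound 2 is the strongest inhibitor of the set. Nothing measured here gives a reason for this difference.

The compounds shown leave open whether the lower number of compound 2 depends on the nitrogen of diethylamino or on its two ethyl chains, a question that a primary amine or dimethylamino at the same place could help separate. They also leave open whether a carboxylic acid, or an ester with a longer chain than ethoxycarbonyl, would stay level with compound 3 or move clearly away from it.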